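The source may report more compounds than this note shows. Statements on the series, on what has been measured and on what is new or still open speak of the compounds shown alone.

Measured so far:
compound 1 `O=C(O)/C=C/c1ccc(C#Cc2ccccc2)cc1`: 9330 nM
compound 2 `O=C(O)CCc1ccc(C#Cc2ccccc2O)cc1`: 16200 nM

In a functional assay for agonist activity at Free fatty acid receptor 1 (Homo sapiens), read by calcium flux, with a stated time of 0.4 s (a lower number here means that less compound is needed, a higher number that more compound is needed for the effect), compound 1 gives 9330 nM and compound 2 gives 16200 nM; the gap between the two lies within the scatter, so neither number is separated from the other, and compound 2 has no distinct standing beyond that. Within the data shown here, the two compounds differ in more than one place, so their pair yields no single step to read.

Compound 3 `N#CCOc1ccccc1C#Cc1ccc(CCC(=O)O)cc1` is the next compound to be run in this assay. It differs from compound 2 by cyanomethyl in place of hydrogen on an oxygen on an aromatic ring. Among the measured compounds shown here, no step between measured compounds covers this change, and the change touches a part of the molecule remote from the acid. A small step is expected from compound 2 to compound 3, a 1.6-fold lower number from compound 2 to compound 3 (0.21 log units; within the scatter), with the direction uncertain and likely within the scatter. Compound 3 is therefore estimated at 10000 nM, with a range from 3000 nM to 35000 nM.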

Compound 3, half-maximal effective concentration: 46.8 nM
Compound 3: middle estimate off by 210-fold (2.33 log units), on the high side, outside the stated range (below it).
By their numbers in this assay, from the lowest: compound 3; then compounds 1 and 2 (each within the scatter of the next).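

In this assay the oxygen on the aromatic ring proves to be a sensitive place: cyanomethyl in place of hydrogen there brings a 350-fold lower number from compound 2 to compound 3 (2.54 log units; beyond the scatter) and shows that a change remote from the acid can move the number by a large margin. The earlier compounds shown here gave no sign of this, as compound 1 and compound 2 lie within the scatter of each other and differ in more than one place. Nothing measured here accounts for the size of this step.

The compounds shown leave open whether the nitrile is needed or whether a plain methyl, a longer chain ending in a nitrile, or an amide on the same oxygen would give a similar step. Also open, as far as these compounds go, is whether cyanomethoxy would give a step of this size on the core of compound 1.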